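A few compounds are considered here, and "the series" means these few. Any claim that something is new, unique, unknown or untested is made for them only; others in the source may bear on it.

Three compounds share one core and differ only in the group carried by the amide nitrogen. Compound 1 `O=C(N[C@@H]1CCNC1)c1cc(-c2ccc(NS(=O)(=O)c3cccc(Cl)c3Cl)cc2)nc2[nH]ncc12` carries pyrrolidin-3-yl there, and in an assay for inhibition of serine/threonine-protein kinase Sgk1 (Homo sapiens), with stated times of 30 min and 60 min, in the presence of a further agent that is not named here (a higher number here means a weaker inhibitor, a lower number a stronger inhibitor), compound 1 reaches < 1 nM, which is a limit of the assay and not a number. Compound 2 `O=C(NC1CCN(CC2CC2)C1)c1cc(-c2ccc(NS(=O)(=O)c3cccc(Cl)c3Cl)cc2)nc2[nH]ncc12` carries 1-(cyclopropylmethyl)pyrrolidin-3-yl, and in this assay compound 2 gives 35 nM; the step of an at least 35-fold higher number from compound 1 to compound 2 (1.54 log units; beyond the scatter) is the only one that can be read. Compound 3 `CCNC(=O)c1cc(-c2ccc(NS(=O)(=O)c3cccc(Cl)c3Cl)cc2)nc2[nH]ncc12` carries ethyl, and in this assay compound 3 gives < 1920 nM, again only a limit. Compound 3 thus stands with a bound rather than a number, so the steps a step that the two limits leave unreadable from compound 1 to compound 3 and a step that the limit leaves unreadable from compound 2 to compound 3 cannot be sized. Compound 4 `CN1CCC(CNC(=O)c2cc(-c3ccc(NS(=O)(=O)c4cccc(Cl)c4Cl)cc3)nc3[nH]ncc23)C1` is the unmeasured one: 1-methylpyrrolidin-3-yl in place of methyl on a saturated chain carbon bound to an amide-type nitrogen. Among the compounds with values here, the one measured step that bears on it, an at least 35-fold higher number from compound 1 to compound 2 (1.54 log units; beyond the scatter), shows that a group on the pyrrolidine nitrogen weakened binding considerably, and compound 4 also carries a substituted pyrrolidine nitrogen, joined through a saturated chain carbon. In this assay compound 4 is therefore expected near 100 nM, between 15 nM and 800 nM, a step that the limit leaves unreadable from compound 3 to compound 4 estimated to stay within the bound of compound 3.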

Compound 4, half-maximal inhibitory concentration: 45 nM
For compound 4 the middle estimate is 2.2-fold (0.35 log units) above the measured one; the measured number falls inside the stated range.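

In this assay, the (1-methylpyrrolidin-3-yl)methyl group and the 1-(cyclopropylmethyl)pyrrolidin-3-yl group cannot be told apart, with a 1.3-fold higher number from compound 2 to compound 4 (0.11 log units; within the scatter). A second compound with a substituted pyrrolidine nitrogen also falls well short of the unsubstituted pyrrolidin-3-yl group, with an at least 45-fold higher number from compound 1 to compound 4 (1.65 log units; beyond the scatter). The steps that involve compound 3 cannot be read because compound 3 has only a limit: the limit of < 1920 nM in this assay, at which 1 of the 4 values shown sits.

Compound 2 and compound 4 differ both in the group on the pyrrolidine nitrogen and in the carbon that joins the ring to the amide-type nitrogen, so these two changes cannot be separated here. Also open, from the compounds shown here alone, is how a pyrrolidin-3-ylmethyl group, with its ring nitrogen unsubstituted, or a piperidin-4-yl group would read in this assay.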